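Aryl amide variation on a shared thiophene-free core, antiproliferative read-out

This account rests on a few compounds, and the source may have more. Where it says the series, first, only, none or still open, it means among the compounds named here.

The measured compounds are compound 1 `NC(=O)c1c(NC(=O)c2ccccc2Br)sc2c1CCN(C(=S)Nc1ccccc1Cl)C2` with 12900 nM, compound 2 `Cc1ccccc1C(=O)Nc1sc2c(c1C(N)=O)CCN(C(=S)Nc1ccccc1Cl)C2` with 11000 nM and compound 3 `COc1ccccc1C(=O)Nc1sc2c(c1C(N)=O)CCN(C(=S)Nc1ccccc1Cl)C2` with 20500 nM, all in a functional assay on MKN-74 cells (Homo sapiens) for antiproliferative activity, with a stated time of 24 h; a lower number here means a stronger inhibitor, a higher number a weaker inhibitor.

Compound 3 carries a 2-methoxyphenyl on the carbonyl carbon where compound 1 carries a bromo-substituted ring and compound 2 a methyl-substituted one. The three numbers sit close together: the step of a 1.6-fold higher number from compound 1 to compound 3 (0.20 log units; within the scatter) and the step of a 1.9-fold higher number from compound 2 to compound 3 (0.27 log units; within the scatter) are both within the scatter, as is the step of a 1.2-fold lower number from compound 1 to compound 2 (0.07 log units; within the scatter). Exchanging the substituent on that aromatic ring has thus produced no step beyond the scatter among these three.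

Compound 4 `Cc1ccc(C(=O)Nc2sc3c(c2C(N)=O)CCN(C(=S)Nc2ccccc2Cl)C3)cc1` is not yet measured. It differs from compound 3 by 4-methylphenyl in place of 2-methoxyphenyl on a carbonyl carbon. For the measured compounds named here, no measured step covers a 4-methylphenyl; the steps that come nearest are the three exchanges on the same carbonyl-bound ring, all within the scatter. Compound 4 is therefore expected to show a 1.5-fold lower number from compound 3 to compound 4 (0.17 log units; within the scatter) in this assay, no step beyond the scatter. The estimate for compound 4 is 14000 nM, ranging from 5000 nM to 40000 nM.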

Compound 4, half-maximal inhibitory concentration: 11300 nM
Compound 4: the middle estimate sits 1.2-fold (0.09 log units) above what was measured; measured number inside the range.
By their numbers in this assay, from the lowest: compounds 2, 4, 1 and 3 (each within the scatter of the next).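

For the compounds shown here, the exchange of 2-methylphenyl for 4-methylphenyl on the carbonyl carbon is the first here to relocate a substituent on the ring rather than replace it, and in this assay it gives a 1.0-fold higher number from compound 2 to compound 4 (0.01 log units; within the scatter). The exchanges of 2-bromophenyl and 2-methoxyphenyl for 4-methylphenyl agree with this, giving a 1.1-fold lower number from compound 1 to compound 4 (0.06 log units; within the scatter) and a 1.8-fold lower number from compound 3 to compound 4 (0.26 log units; within the scatter). Across these four compounds, neither the identity of the substituent nor its place on the ring has produced a step beyond the scatter, and no supporting data are available to explain this.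

The rings shown carry only a bromo, methyl or methoxy group, so the effect of an amine, a carboxylic acid or a longer alkyl chain on the ring remains open. On these data alone, whether any change at this position can produce a step beyond the scatter also remains open.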